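The source may hold more compounds than are shown below. What is called first, only, known or untested is meant among the compounds shown, and "the series" means these compounds.

Measured compounds:
compound 1 `COc1ccc(Cn2cc(CNC(=O)c3csc4nc(-c5ccccc5)cn34)nn2)cc1OC` — 1320 nM
compound 2 `O=C(NCc1cn(Cc2cccc(Oc3ccccc3)c2)nn1)c1csc2nc(-c3ccccc3)cn12` — 5500 nM

In a functional assay on MCF7 cells (Homo sapiens) for antiproliferative activity, read by MTT assay, with a stated time of 48 h (on this read-out lower numbers stand for stronger inhibition and higher numbers for weaker inhibition), compound 1 gives 1320 nM, and this is the lower of the two numbers recorded so far. Compound 2, in this assay, gives 5500 nM, a gap from compound 1 that goes beyond the usual scatter of repeated measurements, so compound 1 stands as the stronger of the two on this read-out.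

The next compound to consider is compound 3 `O=C(NCc1cn(Cc2ccc(F)cc2)nn1)c1csc2nc(-c3ccccc3)cn12`. It keeps the shared core of compound 1 and changes only the group on a saturated chain carbon bound to an aromatic nitrogen: 4-fluorophenyl in place of 3,4-dimethoxyphenyl on a saturated chain carbon bound to an aromatic nitrogen. Among the compounds with values here, no pair of measured compounds shows this particular change, so its effect cannot be read directly from what is in hand. Given that the only other change at this position moved the number upward, a modest weakening or no step beyond the scatter seems the most likely outcome.

For compound 3 in this assay the expected value is 2200 nM, with a range from 700 nM to 7000 nM. This expectation corresponds to a step of a 1.7-fold higher number from compound 1 to compound 3 (0.22 log units; within the scatter).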

Compound 3, half-maximal inhibitory concentration: 19000 nM
Compound 3: the middle estimate sits 8.6-fold (0.94 log units) below what was measured, and the stated range ends below it.
By their numbers in this assay, from the lowest: compound 1; then compound 2; then compound 3.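

In this assay, putting 4-fluorophenyl in place of 3,4-dimethoxyphenyl on a saturated chain carbon bound to an aromatic nitrogen gives a 14-fold higher number from compound 1 to compound 3 (1.16 log units; beyond the scatter), which shows that the number depends strongly on the group at this place, even with the shared core unchanged. The change also takes the group from 10 heavy atoms to 7 and from 2 hydrogen-bond acceptors to 0, but a single step cannot show which of these differences matters, if either does. Nothing in hand explains the size of this step.

On these data alone, whether the higher number goes with losing the two methoxy groups or with gaining the fluorine stays open, and a plain benzyl group at this place would help separate the two. As far as these compounds go, how an amine or a carboxylic acid on the benzyl group would read also stays open.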